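The compounds below may be only part of what the source reports. "The series", "measured", "known", "first", "only" and "open" are said of these compounds alone.

Measured so far in a functional assay on OVCAR-4 cells (Homo sapiens) for inhibition, read by sulforhodamine B assay, with a stated time of 48 h; a lower number here means a stronger inhibitor of growth, a higher number a weaker inhibitor of growth:

compound 1, `COc1cc(-c2nn(-c3cccc(NC(=O)Nc4cc(C(F)(F)F)cc(C(F)(F)F)c4)c3)cc2-c2ccncc2)ccc1Cl` — 9640 nM
compound 2, `COc1cc(-c2nn(-c3cccc(NC(=O)Nc4ccc(Cl)c(Cl)c4)c3)cc2-c2ccncc2)ccc1Cl` — > 50000 nM, a limit of the assay
compound 3, `O=C(Nc1cccc(-n2cc(-c3ccncc3)c(-c3ccc(Cl)c(O)c3)n2)c1)Nc1ccc(Cl)c(Cl)c1` — > 32500 nM, a limit of the assay

Going by the values given here, compound 1 is the only member of the series with a number in this assay. Compound 2 gives only a limit in this assay. Compound 3 likewise gives only a limit in this assay. The difference between the core of compound 1 and the core of compound 2 is not broken down here.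

Compound 2 and compound 3 differ by one change, (hydrogen in place of methyl on an oxygen on an aromatic ring). The resulting step that the two limits leave unreadable from compound 2 to compound 3 cannot be read, since both values are limits, as set out by the limit of > 50000 nM in this assay, at which 1 of the 3 values shown sits, and (the limit of > 32500 nM in this assay, at which 1 of the 3 values shown sits).

Compound 4, `O=C(Nc1cccc(-n2cc(-c3ccncc3)c(-c3ccc(Cl)c(O)c3)n2)c1)Nc1cc(C(F)(F)F)cc(C(F)(F)F)c1`, is not yet measured. It stands to compound 1 as compound 3 stands to compound 2: the change is hydrogen in place of methyl on an oxygen on an aromatic ring, at a place described in the same words, so it is the same change. The measured pair gives no size for it. Compound 1 starts from a number that is weak, 9640 nM. A modest loss would therefore push compound 4 out of the range in which this assay reports a number, while a gain would keep a number.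

With no readable precedent, the step of a 1.6-fold higher number from compound 1 to compound 4 (0.19 log units; within the scatter) is expected to be small. Compound 4 is expected near 15000 nM, plausibly between 5000 nM and 50000 nM, with a real chance that this assay reports only a limit for compound 4.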

Compound 4, concentration for total growth inhibition: 5010 nM
The estimate for compound 4 lay 3.0-fold (0.48 log units) above the measured number; the range from low to high includes it.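

In this assay, methoxy to hydroxy on the core of compound 1, with 4-chloro-3-methoxyphenyl becoming 4-chloro-3-hydroxyphenyl, gives a 1.9-fold lower number from compound 1 to compound 4 (0.28 log units; within the scatter), so the two compounds cannot be told apart on this read-out and the change has no measurable size on this core. Compound 2 and compound 3 carry the same change on another core, but each gives only a limit of the assay, so the step between them cannot be read and offers no size to set beside the new one. The change therefore has a readable result on one core only, which shows that a number in this assay survives the loss of the methyl on the core of compound 1, but does not show that the change carries to the core of compound 2 or behaves alike on both cores.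

Still open, on these data alone, is whether a different group on this oxygen, such as an ethyl or a longer chain ending in an amine or a carboxylic acid, would give a number distinct from those of compound 1 and compound 4. Also open, as far as these compounds go, is whether any group at this place would bring the core of compound 2 into the range where this assay reports a number.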